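A few compounds are considered here, and "the series" means these few. Any claim that something is new, unique, unknown or untested is made for them only; others in the source may bear on it.

In an ADME assay on Huh-7 cells (Homo sapiens) for cytotoxicity, with a stated time of 72 h (a higher number here means that more compound is tolerated, a lower number that less compound is tolerated), compound 2, with the structure `CC(C)CCN1C(=O)C(C2=NS(=O)(=O)c3cc(NS(C)(=O)=O)ccc3N2)=C(O)[C@H]2CCC[C@H]21`, gives > 1000 nM, and this is a limit of the assay rather than a measured number. Compound 1, whose structure is `CC(C)(C)CCN1C(=O)C(C2=NS(=O)(=O)c3cc(NS(C)(=O)=O)ccc3N2)=C(O)C2CCCCC21`, gives > 33000 nM in this assay, which is also a limit. Compound 3, with the structure `CC(C)N1C(=O)C(C2=NS(=O)(=O)c3cc(NS(C)(=O)=O)ccc3N2)=C(O)C2CCCC21`, gives > 33000 nM in this assay, once more a limit. So compound 2 stands at a limit, and the two other values shown are limits as well: the limit of > 1000 nM in this assay, at which 1 of the 3 values shown sits, and (the limit of > 33000 nM in this assay, at which 2 of the 3 values shown sit). Within the data shown here, since no value is a measured number, no step between measured compounds can be given, and nothing here shows whether the change in chain affects how much compound is tolerated.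

Compound 4, with the structure `Cc1cc(CN2C(=O)C(C3=NS(=O)(=O)c4cc(NS(C)(=O)=O)ccc4N3)=C(O)[C@H]3CCC[C@H]32)ccc1F`, differs from compound 2 in one place: 4-fluoro-3-methylphenyl in place of isobutyl on a saturated chain carbon bound to an amide-type nitrogen in a ring. Without any measured step to lean on, the step expected from compound 2 to compound 4 is a step that the limit leaves unreadable from compound 2 to compound 4, that is, no change beyond the usual scatter is expected. Compound 4 is therefore expected to give about 30000 nM in this assay, with a likely range from 8000 nM to 100000 nM, and most probably only a limit would again be reported.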

Compound 4, half-maximal cytotoxic concentration: > 1000 nM
Compound 4 gave a limit, no number; the forecaster's own chance of this, stated with the estimate: 70%; the middle value does not contradict the limit.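

In this assay compound 4 gives > 1000 nM, which is a limit of the assay and not a number. Compound 2 stands at the same limit, so no step between compound 2 and compound 4 can be read: the limit of > 1000 nM in this assay, at which 2 of the 4 values shown sit.

The compounds shown leave open how much of compound 2 or compound 4 is tolerated, and whether 4-fluoro-3-methylphenyl in place of isobutyl changes that at all.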